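This account rests on a few compounds, and the source may have more. Where it says the series, first, only, none or still open, it means among the compounds named here.

In an ADME assay (liver) for metabolic stability, with Liver microsome (Rattus norvegicus) as the target, using microsomes (on this read-out higher numbers stand for fast clearance and lower numbers for slow clearance), compound 2 (`O=C(O)c1csc(-n2nc(-c3ccc(F)cc3)c3ccccc32)n1`) gives 278 mL/min/kg and lies within the scatter of compound 1 (`O=C(O)c1csc(-n2nc(-c3ccccc3)c3cc(F)ccc32)n1`), which gives 345 mL/min/kg in the same read-out. Compound 3 (`O=C(O)c1csc(-n2nc(-c3ccc(C(F)(F)F)cc3)c3ccccc32)n1`) gives 809 mL/min/kg and stands apart from both. Compound 4 (`O=C(O)c1csc(-n2nc(C3=CCCCC3)c3ccccc32)n1`) has not yet been measured in this assay and differs from compound 2 in one place, with cyclohex-1-en-1-yl in place of 4-fluorophenyl on an aromatic carbon. For the measured compounds named here, only one measured step touches this group, and it bears on the change only indirectly: trifluoromethyl in place of fluoro gave a 2.9-fold higher number from compound 2 to compound 3 (0.46 log units; beyond the scatter) and so moved the number modestly upward. Going by the values given here, no measured pair exchanges the aromatic ring itself, so the direction remains uncertain. A step no larger than that one is expected, leaning towards a higher number. For compound 4 the expected step is a 1.5-fold higher number from compound 2 to compound 4 (0.18 log units; within the scatter) as a rough estimate. The estimate for compound 4 is 420 mL/min/kg within an expected range of 190 mL/min/kg to 950 mL/min/kg in this assay.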

Compound 4, clearance: 490 mL/min/kg
Compound 4: the middle estimate sits 1.2-fold (0.07 log units) below what was measured; the range from low to high includes it.
By their numbers in this assay, from the lowest: compounds 2, 1, 4 and 3 (each within the scatter of the next, the first and the last beyond it).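

In this assay the exchange of 4-fluorophenyl for cyclohex-1-en-1-yl gives a 1.8-fold higher number from compound 2 to compound 4 (0.25 log units; within the scatter) and so stays within the scatter. This is the first change shown that replaces the aromatic ring itself at this place on the five-membered aromatic ring with 2 nitrogen, and a non-aromatic carbon ring with one double bond leaves the read-out inseparable from that of compound 2. For the compounds shown here, the only earlier step here, a 2.9-fold higher number from compound 2 to compound 3 (0.46 log units; beyond the scatter) and beyond the scatter, came from a change on the ring that kept it aromatic; nothing available explains either result.

The compounds shown leave open whether a fully saturated cyclohexyl ring would also stay within the scatter of compound 2. Also open, on these data alone, is how a pyridine ring or an amine at this place would read.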